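Working notes: methyl to propyl on compound 1

This account rests on a few compounds, and the source may have more. Where it says the series, first, only, none or still open, it means among the compounds named here.

- Compound 1 `COc1ccc(OS(=O)(=O)c2ccc(N3CCN(C)C3=O)cc2)cc1OC` gives 8500 nM in a functional assay on M21 cells (Homo sapiens) for antiproliferative activity, read by sulforhodamine B assay, with a stated time of 48 h; a lower number here means a stronger inhibitor, a higher number a weaker inhibitor
- Compound 2 `COc1cc(OS(=O)(=O)c2ccc(N3CCN(C)C3=O)cc2)cc(OC)c1OC` gives 54 nM in this assay
- Compound 3 `COc1ccc(OS(=O)(=O)c2ccc(N3CCN(C)C3=O)cc2)cc1` gives > 100000 nM in this assay as a limit, not a number

Compound 1 at 8500 nM is the higher of the two values that are true numbers. The entry for compound 3 is a limit.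

Compound 4 `CCCN1CCN(c2ccc(S(=O)(=O)Oc3ccc(OC)c(OC)c3)cc2)C1=O` is still to be measured. It departs from compound 1 by one change: ethyl in place of hydrogen on a saturated chain carbon bound to an amide-type nitrogen in a ring. Read one bond further out, this is methyl to propyl, and the rest of the structure stays the same.

Two measured steps start from compound 1. One is a 160-fold lower number from compound 1 to compound 2 (2.20 log units; beyond the scatter) and the other is an at least 11-fold higher number from compound 1 to compound 3 (1.07 log units; beyond the scatter). Both are large, but each concerns a methoxy on an aromatic carbon. Neither touches the chain on the ring nitrogen, so they show how far the numbers can move in this series without giving the size of the new step. Within the data shown here, no measured compound carries a chain other than methyl at that place.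

With so little to go on, only a small drift toward a higher number is assumed in this assay, and no step beyond the scatter is expected. The expected step is a 1.2-fold higher number from compound 1 to compound 4 (0.07 log units; within the scatter) as a working estimate. For compound 4 the estimate is 10000 nM, with an expected range from 2500 nM to 40000 nM as its ends.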

Compound 4, half-maximal inhibitory concentration: 28000 nM
Compound 4: middle estimate off by 2.8-fold (0.45 log units), on the low side; measured number inside the range.
By their numbers in this assay, from the lowest: compound 2; then compound 1; then compound 4. At a limit, above all of these: compound 3.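

Going from 3-methyl-2-oxoimidazolidin-1-yl to 2-oxo-3-propylimidazolidin-1-yl gives a 3.3-fold higher number from compound 1 to compound 4 (0.52 log units; beyond the scatter) in this assay and this is the only reading here of a chain other than methyl at this place. The place is therefore not indifferent to the change: ethyl in place of hydrogen on the saturated chain carbon bound to an amide-type nitrogen in a ring moves the number beyond the scatter, toward a weaker inhibitor, though only to a modest extent. The step is smaller than an at least 11-fold higher number from compound 1 to compound 3 (1.07 log units; beyond the scatter) whose far end is a limit, and smaller again than a 160-fold lower number from compound 1 to compound 2 (2.20 log units; beyond the scatter) so in these compounds the methoxy changes on the aromatic carbons move the number further than this chain change does.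

On these data alone, a single step gives no trend, so hydrogen, ethyl or butyl at this place, or a chain ending in an amine or a carboxylic acid, could fall on either side of compound 1, and the size of the same change on compound 2 remains open. No measurement shown accounts for the step.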